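The source may report more compounds than this note shows. Statements on the series, on what has been measured and on what is new or still open speak of the compounds shown alone.

Measured compounds:
- compound 1, `CC(C)(C)c1cc(/C=C/C(=O)NCC2CCN(Cc3ccccc3)CC2)cc(C(C)(C)C)c1O`: 11700 nM
- compound 2, `Cc1ccc(CN2CCC(CCNC(=O)/C=C/c3cc(C(C)(C)C)c(O)c(C(C)(C)C)c3)CC2)cc1`: 8900 nM

Both values come from an assay on isolated protein for inhibition of Amine oxidase [flavin-containing] B (Homo sapiens), read by fluorescence, with stated times of 15 min and 20 min; a higher number here means a weaker inhibitor, a lower number a stronger inhibitor. Compound 2 gives 8900 nM and compound 1 gives 11700 nM; compound 2 carries the lower of the two numbers, but the gap between them lies within the usual scatter of this assay, so no order between the two can be claimed. The two compounds share the same core and differ only in the group on the saturated chain carbon bound to the amine nitrogen in the ring.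

Compound 3, `CC(C)(C)c1cc(/C=C/C(=O)NCCC2CCN(Cc3ccc(F)cc3F)CC2)cc(C(C)(C)C)c1O`, is not yet measured. It differs from compound 2 in one place: 2,4-difluorophenyl in place of 4-methylphenyl on a saturated chain carbon bound to an amine nitrogen in a ring. Going by the values given here, no measured pair shows this particular exchange, so its effect on this assay is unknown. Among the compounds with values here, the single measured pair, compound 1 against compound 2, shows that an exchange at this position can pass without a change beyond the scatter. On that basis compound 3 is expected to stay close to compound 2, with a step of a 1.0-fold higher number from compound 2 to compound 3 (0.00 log units; within the scatter) that is expected to fall within the scatter. The estimate for compound 3 in this assay is 9000 nM, with a range from 4000 nM to 20000 nM.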

Compound 3, half-maximal inhibitory concentration: 12500 nM
Beside the measured number, compound 3's estimate is 1.4-fold (0.14 log units) below it; the measured number falls inside the stated range.
By their numbers in this assay, from the lowest: compounds 2, 1 and 3 (each within the scatter of the next).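

In this assay, replacing 4-methylphenyl with 2,4-difluorophenyl on a saturated chain carbon bound to an amine nitrogen in a ring gives a 1.4-fold higher number from compound 2 to compound 3 (0.15 log units; within the scatter). Going by these compounds alone, this is the first reading of an exchange on the aromatic ring itself, read one bond further out as 4-methylbenzyl to 2,4-difluorobenzyl, and it shows that removing the methyl group and adding two fluorine atoms leaves the number within the scatter. Nothing available explains why this exchange has so little effect on the reading, and no measurement beyond the assay values bears on the result.

The compounds shown leave open whether any group at this place can move the number beyond the scatter, since all those shown are benzyl groups with a carbon-only aromatic ring; a pyridylmethyl group, a benzoyl group or a simple methyl group on the ring amine nitrogen would test this more sharply. From the compounds shown here alone, it also remains open whether a stronger inhibitor could come from a change elsewhere, such as a longer chain between the amide and the ring bearing the amine nitrogen.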